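A few compounds are considered here, and "the series" means these few. Any claim that something is new, unique, unknown or untested is made for them only; others in the source may bear on it.

In a physicochemical assay for solubility, in phosphate buffer, measured as kinetic solubility, at pH 7.4 (on this read-out higher numbers stand for higher solubility and lower numbers for lower solubility), compound 3 (`Cc1ccc(-c2nc(CN3CCC(C(=O)NCCCN4C[C@H](C)C[C@H](C)C4)CC3)c(C)o2)cc1`) gives > 69 ug/mL, a limit and not a number. In this assay compound 1 (`Cc1cccc(-c2nc(CN3CCC(C(=O)NCCCN4C[C@H](C)C[C@H](C)C4)CC3)c(C)o2)c1`) gives > 69 ug/mL, also a limit. In this assay compound 2 (`COc1cccc(Br)c1-c1nc(CN2CCC(C(=O)NCCCN3C[C@H](C)C[C@H](C)C3)CC2)c(C)o1`) gives > 83 ug/mL, again a limit. No number has been read for any of the three, so compound 3 has no rank among them.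

The next change leads to compound 4 (`Cc1cccc(C)c1-c1nc(CN2CCC(C(=O)NCCCN3C[C@H](C)C[C@H](C)C3)CC2)c(C)o1`): 2,6-dimethylphenyl in place of 4-methylphenyl on an aromatic carbon. In words, 2,6-dimethylphenyl stands in place of 4-methylphenyl, on an aromatic carbon of a five-membered aromatic ring with 1 nitrogen and 1 oxygen.

The nearest measured change is a step that the two limits leave unreadable from compound 2 to compound 3, with 4-methylphenyl in place of 2-bromo-6-methoxyphenyl. Two further changes at the same place are a step that the two limits leave unreadable from compound 1 to compound 2 and a step that the two limits leave unreadable from compound 1 to compound 3. None of these steps has a readable size, so they give neither a size nor a direction to carry over. No step beyond the scatter is therefore expected in this assay, and the expected step is a step that the limit leaves unreadable from compound 3 to compound 4. A further limit is the likeliest report for the new compound. Compound 4 is estimated at 71 ug/mL, with an expected range from 50 ug/mL to 90 ug/mL.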

Compound 4, solubility: 55.9 ug/mL
The estimate for compound 4 lay 1.3-fold (0.10 log units) above the measured number; the measured number falls inside the stated range.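

In this assay compound 4 is the only compound shown that gives a number and not a limit, 55.9 ug/mL, so 2,6-dimethylphenyl gives this position, on an aromatic carbon of a five-membered aromatic ring with 1 nitrogen and 1 oxygen, its first readable value. That number turns three comparisons into floors, with an at least 1.2-fold lower number from compound 3 to compound 4 (0.09 log units; that floor lies within the scatter) and an at least 1.2-fold lower number from compound 1 to compound 4 (0.09 log units; that floor lies within the scatter) and an at least 1.4-fold lower number from compound 2 to compound 4 (0.17 log units; that floor lies within the scatter) as the only sizes available, and none of them shows a real difference between the groups. The steps among compound 1, compound 2 and compound 3 still cannot be read, and compound 3 remains a limit: the limit of > 69 ug/mL in this assay, at which 2 of the 4 values shown sit.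

As far as these compounds go, whether 2,6-dimethylphenyl differs at all from 4-methylphenyl, 3-methylphenyl or 2-bromo-6-methoxyphenyl stays open until those three groups have numbers and not limits. Also open is how a phenyl group carrying an amine or a carboxylic acid would read at this position in this assay, where the compounds shown offer only methyl, bromo and methoxy substituents on that ring.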